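The source may hold more compounds than are shown below. What is called first, only, known or untested is meant among the compounds shown, and "the series" means these compounds.

Series notes. Three compounds have so far been run in a functional assay on P388 cells (Mus musculus) for inhibition, tested at 0.1 uM; on this read-out higher numbers stand for a stronger effect at the one concentration tested and lower numbers for a weaker effect. Compound 1 `COc1ccc2c(c1)c(-c1cc(C(F)(F)F)c(C#N)c(-c3cn(S(=O)(=O)c4ccc(C)cc4)c4ccc(OC)cc34)n1)cn2S(=O)(=O)c1ccc(C)cc1` gives 1.7% in this assay. Compound 2 `COc1ccc2c(-c3cc(C(F)(F)F)c(C#N)c(-c4cn(S(=O)(=O)c5ccc(C)cc5)c5cc(OC)ccc45)n3)cn(S(=O)(=O)c3ccc(C)cc3)c2c1` gives 5.1%, and compound 3 `Cc1ccc(S(=O)(=O)n2cc(-c3cc(C(F)(F)F)cc(-c4cn(S(=O)(=O)c5ccc(C)cc5)c5ccccc45)n3)c3ccccc32)cc1` gives 15.7%. Compound 1 holds the lowest of the three numbers: its gap to compound 2 lies within the usual scatter of this measurement, whereas its gap to compound 3 lies beyond it. Among the measured compounds shown here, no two measured compounds differ in only one place, so no single-change step can be drawn from the measured set.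

Compound 4 `COc1ccc2c(c1)c(-c1cc(C(F)(F)F)cc(-c3cn(S(=O)(=O)c4ccc(C)cc4)c4ccc(OC)cc34)n1)cn2S(=O)(=O)c1ccc(C)cc1` has not yet been measured. It differs from compound 1 as follows: hydrogen in place of cyano on an aromatic carbon. The change sits on an aromatic carbon of a six-membered aromatic ring with one nitrogen, ortho to a trifluoromethyl group and two atoms from the ring nitrogen.

Compound 3 also carries hydrogen at that position, but it lacks the methoxy groups of compound 1, so its value is only a loose pointer and not a step. For this assay a modest rise is expected, most likely not clearly beyond the scatter. Compound 4 is estimated at 8%, with a range from 0% to 20%. That would amount to an expected step of a number 6.3 percentage points higher from compound 1 to compound 4 (within the scatter).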

Compound 4, a percentage reported as inhibition, at one concentration (the size of the read-out at that concentration, not a potency): 9.3%
Compound 4: middle estimate off by 1.3 percentage points, on the low side, and the stated range covers the measured number.
By their numbers in this assay, from the lowest: compounds 1, 2, 4 and 3 (each within the scatter of the next, the first and the last beyond it).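

Among the compounds shown here, this is the first single-change step, and it isolates the cyano on the aromatic carbon ortho to a trifluoromethyl group and two atoms from the ring nitrogen. In this assay, hydrogen in place of that cyano gives a step that stays within the scatter (a number 7.6 percentage points higher from compound 1 to compound 4 (within the scatter)), so at the one concentration tested this read-out does not separate the two compounds, and the cyano, with its triple bond and its hydrogen-bond acceptor, is not shown to matter at this position on the core of compound 1. Nothing on hand explains the size of this step or gives a measured property of either compound that bears on it.

As far as these compounds go, only cyano and hydrogen have been seen at this position, so it remains open whether an amine, a carboxylic acid or a longer chain such as an ethyl ester there would give a step beyond the scatter. From the compounds shown here alone, it also remains open whether the same exchange would read the same way on a core without the methoxy groups, and a single concentration says nothing about potency.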